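Swapping the Amide Tail: Expected Cytotoxicity of Compound 3

A few compounds are considered here, and "the series" means these few. Any claim that something is new, unique, unknown or untested is made for them only; others in the source may bear on it.

Compound 1, `Cn1c(-c2ccc(N)cc2)nc2cc(C(F)(F)F)ccc21`: 85000 nM
Compound 2, `Cn1c(-c2ccc(NC(=O)CN3CCN(c4ccccc4)CC3)cc2)nc2cc(C(F)(F)F)ccc21`: 100000 nM

Both were tested in an ADME assay on BHK cells (Mesocricetus auratus) for cytotoxicity, read by MTT assay, with a stated time of 96 h; on this read-out lower numbers stand for higher toxicity in this test and higher numbers for lower toxicity in this test. Compound 2 gives the highest of the two numbers, but compound 1 sits within the scatter of it, so the two cannot be told apart. Compound 3, `Cn1c(-c2ccc(NC(=O)CN3CCCCC3)cc2)nc2cc(C(F)(F)F)ccc21`, carries one change from compound 2: piperidin-1-yl in place of 4-phenylpiperazin-1-yl on a saturated chain carbon bound to a carbonyl carbon. Among the compounds with values here, no step between measured compounds is known, and the two measured values show no gap beyond the scatter, so in this assay no step beyond the scatter is expected in either direction. Compound 3 is expected to give 85000 nM, between 40000 nM and 160000 nM. The expected step, a 1.2-fold lower number from compound 2 to compound 3 (0.07 log units; within the scatter), stays within the scatter.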

Compound 3, half-maximal cytotoxic concentration: > 100000 nM
Compound 3 ended at the assay's limit; the forecaster's own chance of this, stated with the estimate: 25%; middle value at least 1.1-fold (0.07 log units) from the limit.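

In this assay, compound 3 stands at a limit of the test, > 100000 nM, not at a number. Piperidin-1-yl in place of 4-phenylpiperazin-1-yl therefore gives a number no lower from compound 2 to compound 3 (the limit leaves the size open), so the phenyl-bearing tail is not needed to keep this read-out high, though the size of that step cannot be read because the read-out ends at a limit: the limit of > 100000 nM in this assay, at which 1 of the 3 values shown sits. The piperidine amide tail on the nitrogen of compound 1 gives an at least 1.1-fold higher number from compound 1 to compound 3 (0.07 log units; that floor lies within the scatter), a floor that shows no change beyond the scatter. On these data alone, whether a tail ending in a carboxylic acid, or a longer chain before the piperidine ring, would give a lower number stays open.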